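This account rests on a few compounds, and the source may have more. Where it says the series, first, only, none or still open, it means among the compounds named here.

Compound 2 `COc1cc(-c2nnc3n2NC(c2ccco2)C(C(=O)c2ccc(Cl)cc2)S3)cc(OC)c1OC` is one of three close relatives sharing a core, differing only in the aryl group attached to the carbonyl carbon. In a functional assay on PC-3 cells (Homo sapiens) for cytotoxicity, read by MTT assay, with a stated time of 48 h (on this read-out lower numbers stand for stronger inhibition and higher numbers for weaker inhibition), compound 2 gives 67800 nM. Compound 3 `COc1ccc(C(=O)C2Sc3nnc(-c4cc(OC)c(OC)c(OC)c4)n3NC2c2cccs2)cc1` gives 95900 nM in this assay, and the two numbers lie within the usual scatter of each other. Compound 1 `COc1cc(-c2nnc3n2NC(c2ccco2)C(C(=O)c2ccccc2F)S3)cc(OC)c1OC` gives > 100000 nM in this assay; that value is a limit of the assay rather than a number, as the limit of > 100000 nM in this assay, at which 1 of the 3 values shown sits, shows. Compound 2 therefore has the lowest of the two numbers, but not by a margin that means anything.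

Compound 4 `COc1cc(-c2nnc3n2NC(c2ccco2)C(C(=O)c2ccc(F)c(F)c2)S3)cc(OC)c1OC` carries the change (3,4-difluorophenyl in place of 4-chlorophenyl on a carbonyl carbon). For the measured compounds named here, the only measured step that touches this position is an at least 1.4-fold lower number from compound 1 to compound 2 (0.16 log units; that floor lies within the scatter), where one halogenated phenyl replaced another and the outcome stayed near the scatter. Exchanging a chlorine-bearing phenyl for a fluorine-bearing phenyl here is expected to move the number by little or nothing beyond the scatter, so the expected step is a 1.0-fold higher number from compound 2 to compound 4 (0.01 log units; within the scatter). Compound 4 is estimated at 70000 nM in this assay, with a range from 30000 nM to 160000 nM, and a real chance that only a limit is reported.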

Compound 4, half-maximal inhibitory concentration: 36000 nM
Compound 4: middle estimate off by 1.9-fold (0.29 log units), on the high side, within the range that was stated.
By their numbers in this assay, from the lowest: compounds 4, 2 and 3 (each within the scatter of the next, the first and the last beyond it). At a limit, above all of these: compound 1.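

Putting 3,4-difluorophenyl in place of 4-chlorophenyl on the carbonyl carbon gives a 1.9-fold lower number from compound 2 to compound 4 (0.27 log units; within the scatter) in this assay, so these two groups cannot be told apart here, and the lower printed number for compound 4 should not be read as a real gain. The more informative comparison is an at least 2.7-fold lower number from compound 1 to compound 4 (0.44 log units; beyond the scatter), the first step at this position shown to lie beyond the scatter, which means that the choice of halogenated phenyl on the carbonyl carbon can make a measurable, if modest, difference. That step has only a floor for its size, since compound 1 is reported at a limit of the assay and not at a number: the limit of > 100000 nM in this assay, at which 1 of the 4 values shown sits.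

Because 3,4-difluorophenyl differs from 2-fluorophenyl both in its number of fluorines and in where they sit, the compounds shown cannot separate these two changes. Going by these compounds, it also remains open whether a phenyl group carrying something other than a halogen, such as an amine or a carboxylic acid, would fall in the same range on this carbonyl carbon or move the number well beyond the scatter.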